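Fluoro to methyl: a step still to be measured

This account rests on a few compounds, and the source may have more. Where it says the series, first, only, none or still open, it means among the compounds named here.

Measured in a physicochemical assay for lipophilicity, read by HPLC, at pH 7.4; a higher number here means a more lipophilic compound, a lower number a more polar compound:
- compound 1 (`Cc1ccc([C@@H](C)Oc2cc3onc(CCC(=O)O)c3cc2Cl)nc1`) (2.42)
- compound 2 (`C[C@@H](Oc1cc2oc(=O)n(CCC(=O)O)c2cc1Cl)c1ccc(F)cn1`) (1.98)

Of the two, compound 2 stands lower (1.98), and the gap to compound 1 (2.42) lies beyond the scatter. Compound 3 (`Cc1ccc([C@@H](C)Oc2cc3oc(=O)n(CCC(=O)O)c3cc2Cl)nc1`) has not yet been measured. It differs from compound 2 in one place (methyl in place of fluoro on an aromatic carbon): methyl in place of fluoro on an aromatic carbon, turning 5-fluoropyridin-2-yl into 5-methylpyridin-2-yl. Among the compounds with values here, no measured pair shows this change, so the expectation rests on the change alone. A small upward step is expected in this assay (a number 0.32 log units higher from compound 2 to compound 3 (beyond the scatter)), around the edge of the scatter. The estimate for compound 3 is 2.3 (expected range 1.95 to 2.65).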

Compound 3, distribution coefficient: 2.02
The estimate for compound 3 lay 0.28 log units above the measured number; low and high end bracket the measured number.
By their numbers in this assay, from the lowest: compounds 2 and 3 (each within the scatter of the next); then compound 1.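

Read in this assay the change from 5-fluoropyridin-2-yl to 5-methylpyridin-2-yl gives a number 0.04 log units higher from compound 2 to compound 3 (within the scatter) so compound 2 and compound 3 cannot be told apart by this read-out. On this aromatic carbon, with the rest of the molecule held the same, fluoro and methyl are thus interchangeable as far as this number goes. No measurement shown offers a reason for this result.

From the compounds shown here alone, whether a larger group at this position, such as methoxy or an amine, would stay equally close remains open. So does whether the same change would read alike on the core of compound 1.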